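The source may report more compounds than this note shows. Statements on the series, on what has been measured and on what is new or still open speak of the compounds shown alone.

Measured compounds:
- compound 1, `CNCC(=O)NC[C@@H]1CCCc2cc(S(=O)(=O)c3cccc(F)c3)ccc21`: 0.159 nM
- compound 2, `N=C(N)NC(=O)C[C@@H]1CCCc2cc(S(=O)(=O)c3cccc(F)c3)ccc21`: 0.631 nM
- compound 3, `NC(=O)NC[C@@H]1CCCc2cc(S(=O)(=O)c3cccc(F)c3)ccc21`: 0.2 nM

These three share one core and differ only in the group hanging from the saturated ring carbon. In an assay on isolated protein for displacement of a labelled ligand from 5-hydroxytryptamine receptor 6 (Homo sapiens) (a higher number here means a weaker inhibitor, a lower number a stronger inhibitor), compound 3 gives 0.2 nM, which places it second highest of the three numbers: the nearer gap is a 1.3-fold higher number from compound 1 to compound 3 (0.10 log units; within the scatter), while the wider one is a 3.2-fold lower number from compound 2 to compound 3 (0.50 log units; beyond the scatter).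

Compound 4, `COC(=O)NC[C@@H]1CCCc2cc(S(=O)(=O)c3cccc(F)c3)ccc21`, is made from compound 3 by methoxy in place of amino on a carbonyl carbon. The measured steps all probe this same tail. The urea-to-amide swap between compound 1 and compound 3 changed little, whereas the guanidine-type tail of compound 2 cost something, as shown by a 4.0-fold higher number from compound 1 to compound 2 (0.60 log units; beyond the scatter). Going by the values given here, no measured step removes a hydrogen-bond donor from this carbonyl, so the expectation rests on the general tolerance of this tail: a step of about a 2.0-fold higher number from compound 3 to compound 4 (0.30 log units; within the scatter) is expected, toward a somewhat higher number. Compound 4 is therefore estimated at 0.4 nM, within a range of 0.1 nM to 1.6 nM.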

Compound 4, inhibition constant: 1.59 nM
For compound 4 the middle estimate is 4.0-fold (0.60 log units) below the measured one; low and high end bracket the measured number.
By their numbers in this assay, from the lowest: compounds 1 and 3 (each within the scatter of the next); then compound 2; then compound 4.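

Placing methoxy instead of amino on this carbonyl carbon gives an 8.0-fold higher number from compound 3 to compound 4 (0.90 log units; beyond the scatter) in this assay, so this position is less forgiving than the closely matched values of compounds 1 and 3 suggested. The same tail also falls behind the other two compounds, with a 2.5-fold higher number from compound 2 to compound 4 (0.40 log units; beyond the scatter) and a 10-fold higher number from compound 1 to compound 4 (1.00 log units; beyond the scatter), which makes compound 4 the weakest of the four in this assay. Nothing measured here connects this loss to the hydrogen-bond donor leaving with the amino group, or to any other feature.

As far as these compounds go, it remains open whether a methylamino group on this carbonyl carbon would stay close to compound 3 or move toward compound 4. A plain methyl group at the same place would test whether either the amino nitrogen or the methoxy oxygen is needed at all.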